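Swapping the cyanoimine ring for a triazolylmethyl group

The source may hold more compounds than are shown below. What is called first, only, known or untested is meant among the compounds shown, and "the series" means these compounds.

Compound 3 `CC(C)C(c1ccc(-c2ccc3cccc(F)c3c2)[nH]c1=O)N1CCN/C1=N\C#N` carries a five-membered non-aromatic ring on the saturated chain carbon bound to an aromatic carbon and a saturated chain carbon. Within the data shown here, in an ADME assay on microsomes from liver (Mus musculus) for metabolic stability (a lower number here means that the compound disappears faster, a higher number that the compound lasts longer), compound 3 gives 0.207 h, the only actual number among the three measured compounds. Compound 1 `CCn1ncc2c(F)cc(-c3ccc(C(CC)(CC)c4nnc(C)[nH]4)c(=O)[nH]3)cc21` reaches the limit, giving > 3 h in this assay. Compound 2 `CCn1ncc2c(F)cc(-c3ccc(C(CC)(CC)c4ncn(C)n4)c(=O)[nH]3)cc21` likewise gives the limit > 3 h in this assay. Among the measured compounds shown here, the step between them, a step that the two limits leave unreadable from compound 1 to compound 2, cannot be read because both sit at the limit (the limit of > 3 h in this assay, at which 2 of the 3 values shown sit), so no measured step tells how large a change of this kind is.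

Compound 4 `CC(C)C(Cc1nnc[nH]1)c1ccc(-c2ccc3cccc(F)c3c2)[nH]c1=O` differs from compound 3 as follows: a group of 6 heavy atoms (3 carbon, 3 nitrogen; one five-membered aromatic ring with 3 hetero atoms) in place of a group of 8 heavy atoms (4 carbon, 4 nitrogen; one five-membered non-aromatic ring with 2 hetero atoms), on a saturated chain carbon bound to an aromatic carbon and a saturated chain carbon. For the measured compounds named here, no measured step covers this exact exchange, so the expectation rests only on where compound 3 stands. Compound 4 is estimated at 0.5 h in this assay, within 0.15 h to 2 h. The expected step of a 2.4-fold higher number from compound 3 to compound 4 (0.38 log units; beyond the scatter) is a modest rise, not clearly beyond the scatter.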

Compound 4, half-life: < 0.0667 h
Compound 4 was reported as a limit (the forecaster's own chance of this, stated with the estimate: 15%); middle value at least 7.4-fold (0.87 log units) away from the limit.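

In this assay, putting (4H-1,2,4-triazol-3-yl)methyl in place of the five-membered non-aromatic ring, on the saturated chain carbon bound to an aromatic carbon and a saturated chain carbon, gives an at least 3.1-fold lower number from compound 3 to compound 4 (0.49 log units; beyond the scatter). Among these compounds, this is the first step that can be read at all, and it shows that the group at this place can shift the half-life beyond the scatter, here towards faster disappearance. Its full size stays unknown because compound 4 is reported only as a limit, not as a number: the limit of < 0.0667 h in this assay, at which 1 of the 4 values shown sits.

On these data alone, whether the triazole ring or its one-carbon link matters more stays open, as both enter together in compound 4. Also open, as far as these compounds go, is what a carboxylic acid, a primary amine or a longer chain ending in the same triazole would give at this place.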